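Fluorophenoxy Replaces a Methoxyphenyl Thioether on the Core

A few compounds are considered here, and "the series" means these few. Any claim that something is new, unique, unknown or untested is made for them only; others in the source may bear on it.

Compound 3 `COc1ccc(Sc2nc3cc(N)cc(N)c3nc2-c2ccccc2)cc1` shares its core with compound 1 `Nc1cc(N)c2nc(-c3ccccc3)c(Oc3ccc(Cl)c(Cl)c3)nc2c1` and compound 2 `CCOC(=O)[C@H](CCC(=O)O)NC(=O)c1ccc(Sc2nc3cc(N)cc(N)c3nc2-c2ccccc2)cc1`. In a functional assay on SNB-19 cells (Homo sapiens) for inhibition, read by sulforhodamine B assay, with a stated time of 48 h (a higher number here means a weaker inhibitor of growth, a lower number a stronger inhibitor of growth), compound 1 gives 52500 nM. For compound 2 this assay reports only a limit, < 100000 nM. For compound 3 as well this assay reports only a limit, < 100000 nM. Compound 3 thus stands at a limit rather than at a number, and the limit of < 100000 nM in this assay, at which 2 of the 3 values shown sit, is where two of the three values shown sit. The change from compound 3 to compound 4 `Nc1cc(N)c2nc(-c3ccccc3)c(Oc3ccc(F)cc3)nc2c1` is 4-fluorophenoxy in place of (4-methoxyphenyl)sulfanyl on an aromatic carbon. For the measured compounds named here, the one measured step that bears on it is a step that the limit leaves unreadable from compound 1 to compound 3, which the limit leaves unreadable, so its size offers no guide. What remains is compound 1, whose 3,4-dichlorophenoxy group resembles the entering 4-fluorophenoxy group and which gives 52500 nM. Compound 4 is therefore expected to land near that figure, at about 50000 nM, with a range from 15000 nM to 100000 nM. This estimate means a step that the limit leaves unreadable from compound 3 to compound 4, which is expected to remain uncertain since it starts from a limit.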

Compound 4, concentration for total growth inhibition: 33900 nM
Compound 4: middle estimate off by 1.5-fold (0.17 log units), on the high side; the range from low to high includes it.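

Compound 4 gives a second readable number for a phenoxy group at this position on the shared core, so the ring on the oxygen can now be compared directly. In this assay, 4-fluorophenyl in place of 3,4-dichlorophenyl gives a 1.5-fold lower number from compound 1 to compound 4 (0.19 log units; within the scatter), so these two phenoxy groups cannot be told apart here. Compound 3 has only a limit, so the step that replaces its (4-methoxyphenyl)sulfanyl group, like the other step from that compound, cannot be read: the limit of < 100000 nM in this assay, at which 2 of the 4 values shown sit.

The effect of sulfur against oxygen as the linking atom stays open, as the sulfur compounds shown carry different ring groups and have only limits. Going by these compounds, it also remains open whether a phenoxy ring bearing an amine or a carboxylic acid in place of halogen would separate from these two values.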